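A few compounds are considered here, and "the series" means these few. Any claim that something is new, unique, unknown or untested is made for them only; others in the source may bear on it.

Measured compounds:
compound 1 `COc1cccc(C(=O)N/N=C/C2=C(Cl)c3cc(C)c(C)cc3CCC2)c1C`: 170 nM
compound 2 `Cc1cc2c(cc1C)C(Cl)=C(/C=N/NC(=O)c1cccc(Cl)c1)CCC2`: a limit, > 100000 nM
compound 3 `Cc1cc2c(cc1C)C(Cl)=C(/C=N/NC(=O)c1ccccc1N)CCC2`: 36300 nM

All three share one core and differ only in the aryl group on the carbonyl carbon. In a functional assay on IMR-32 cells (Homo sapiens) for inhibition, read by sulforhodamine B assay, with a stated time of 48 h (a lower number here means a stronger inhibitor of growth, a higher number a weaker inhibitor of growth), compound 1 gives 170 nM. Compound 2 gives only a limit in this assay, > 100000 nM, which is not a number (the limit of > 100000 nM in this assay, at which 1 of the 3 values shown sits). Compound 3 gives 36300 nM, the highest of the two numbers shown; the nearest number is that of compound 1, and the step is a 210-fold higher number from compound 1 to compound 3 (2.33 log units; beyond the scatter).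

Compound 4 `Cc1cc2c(cc1C)C(Cl)=C(/C=N/NC(=O)c1cccc(I)c1)CCC2` differs from compound 3 in one place: 3-iodophenyl in place of 2-aminophenyl on a carbonyl carbon. Among the compounds with values here, the steps that bear on this are an at least 580-fold higher number from compound 1 to compound 2 (2.76 log units; beyond the scatter) and an at least 2.7-fold lower number from compound 2 to compound 3 (0.44 log units; beyond the scatter). The 3-iodophenyl of compound 4 is, like the 3-chlorophenyl of compound 2, a halogen on the phenyl ring, and compound 2 sat at the limit. Going from compound 3 to compound 4 is therefore expected to raise the number, roughly undoing the step from compound 2 to compound 3, so a 2.2-fold higher number from compound 3 to compound 4 (0.34 log units; beyond the scatter) is expected. Compound 4 is estimated at 80000 nM, within a range from 15000 nM to 300000 nM, with a real chance that this assay again reports only a limit.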

Compound 4, concentration for 50% growth inhibition: 1900 nM
Compound 4: middle estimate off by 42-fold (1.62 log units), on the high side; the measured number lies below the stated range.
By their numbers in this assay, from the lowest: compound 1; then compound 4; then compound 3. At a limit, above all of these: compound 2.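

The sharpest new comparison is iodo in place of chloro on an aromatic carbon, with an at least 52-fold lower number from compound 2 to compound 4 (1.72 log units; beyond the scatter) in this assay, so a halogen on this phenyl ring does not by itself remove growth inhibition; which halogen it is matters. Going by these compounds, compound 2 gives only a limit, not a number, so the true size of this step is unknown: the limit of > 100000 nM in this assay, at which 1 of the 4 values shown sits. The 3-iodophenyl also improves on the 2-aminophenyl, with a 19-fold lower number from compound 3 to compound 4 (1.28 log units; beyond the scatter), but it does not match the 3-methoxy-2-methylphenyl, with an 11-fold higher number from compound 1 to compound 4 (1.05 log units; beyond the scatter).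

On these data alone, whether a bromo group in place of the iodo would fall nearer compound 2 or compound 4 stays open. So does how much of the strength of compound 1 comes from its methoxy group and how much from its methyl group.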